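The compounds below may be only part of what the source reports. "The series", "measured", "known", "first", "only" and "open" are said of these compounds alone.

Measured compounds in a functional assay on HEL cells (Homo sapiens) for cytotoxicity; a lower number here means that less compound is tolerated, a higher number that more compound is tolerated:

compound 1, `CCCCCCCc1cc2cn([C@H]3C[C@H](O)[C@@H](CO)O3)c(=O)nc2o1` — > 50000 nM
compound 2, `C=CCCCc1cc2cn([C@H]3C[C@H](O)[C@@H](CO)O3)c(=O)nc2o1` — > 200000 nM

Both values are limits of this assay rather than numbers. For compound 1 the read-out stops at the limit of > 50000 nM in this assay, at which 1 of the 2 values shown sits. For compound 2 the read-out stops at the limit of > 200000 nM in this assay, at which 1 of the 2 values shown sits. Because both ends are limits, the step that the two limits leave unreadable from compound 1 to compound 2 cannot be sized; all that can be said is that neither compound reached a half-maximal cytotoxic concentration within the tested range.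

The next compound, compound 3, `C=CCCCCc1cc2cn([C@H]3C[C@H](O)[C@@H](CO)O3)c(=O)nc2o1`, differs from compound 2 in one place: allyl in place of vinyl on a saturated chain carbon, three bonds along the chain from an aromatic carbon. Among the measured compounds shown here, the only measured step is the one from compound 1 to compound 2, and it is unreadable, so there is no measured guide to how lengthening the chain by one carbon moves the value in this assay. The two measured compounds, which differ more widely in this same chain than compound 2 and compound 3 do, both sit at limits.

On that basis compound 3 is expected to behave like compound 2, with an estimated step of a number no higher from compound 2 to compound 3 (the limit leaves the size open) in this assay, likely again only a limit. The estimate for compound 3 is 200000 nM, expected to fall between 50000 nM and 500000 nM.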

Compound 3, half-maximal cytotoxic concentration: > 200000 nM
Compound 3 gave a limit, no number (the forecaster's own chance of this, stated with the estimate: 85%); the middle value lies on the limit itself.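

Compound 3 gave a limit rather than a number in this assay, as did compound 1 and compound 2, and none of the steps among these three compounds can be read. The compounds shown leave open the half-maximal cytotoxic concentration of each one, and whether the length of the chain moves it at all.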